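The source may hold more compounds than are shown below. What is called first, only, known or untested is meant among the compounds shown, and "the series" means these compounds.

Of the compounds shown here, three that share one core have been tested in an ADME assay on KB cells (Homo sapiens) for cytotoxicity; on this read-out higher numbers stand for an effect only at larger amounts of compound and lower numbers for an effect already at smaller amounts. Compound 1 `COC(=O)N1[C@@H]2C=C[C@@](OC)(C(=O)c3c2cc(OC)c(OC)c3OCc2ccccc2)N1C(=O)OC` gives > 300 ug/mL, which is a limit of the assay and not a number. Compound 2 `CCCOc1c(OC)c(OC)cc2c1C(=O)[C@]1(OC)C=C[C@H]2N(C(=O)OCC)N1C(=O)OCC` gives > 300 ug/mL, again a limit. Compound 3 `COc1cc2c(c(OCc3ccc(F)cc3)c1OC)C(=O)[C@]1(OC)C=C[C@H]2N(C(=O)OCC(C)C)N1C(=O)OCC(C)C` gives > 300 ug/mL, also a limit. Compound 3 therefore stands with the other two, at the limit of > 300 ug/mL in this assay, at which 3 of the 3 values shown sit.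

Compound 4 `COc1cc2c(c(OCc3ccccc3F)c1OC)C(=O)[C@]1(OC)C=C[C@H]2N(C(=O)OCC(C)C)N1C(=O)OCC(C)C` differs from compound 3 in one place: 2-fluorophenyl in place of 4-fluorophenyl on a saturated chain carbon bound to an oxygen on an aromatic ring. A 2-fluorophenyl takes the place of a 4-fluorophenyl on a saturated chain carbon bound to an oxygen on an aromatic ring, so the two compounds have the same atoms, joined differently. Among the measured compounds shown here, no measured pair shows what this change does. The expectation rests on compound 3, whose > 300 ug/mL is a limit. No step beyond the usual scatter is expected in this assay, in either direction, and the estimated step is a number no higher from compound 3 to compound 4 (the limit leaves the size open). Compound 4 is estimated at 300 ug/mL, with an expected range from 150 ug/mL to 400 ug/mL.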

Compound 4, concentration for half-maximal effect: 109 ug/mL
Compound 4: the middle estimate sits 2.8-fold (0.44 log units) above what was measured, outside the stated range (below it).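

Exchanging the 4-fluorophenyl for a 2-fluorophenyl on a saturated chain carbon bound to an oxygen on an aromatic ring gives, in this assay, an at least 2.7-fold lower number from compound 3 to compound 4 (0.43 log units; beyond the scatter). Going by these compounds, the same atoms, joined differently, are thus enough to change the read-out at this place, although the true size of the step stays open. Compound 4 is also the only compound shown that gives a number rather than a limit, and the others all stand at that limit: the limit of > 300 ug/mL in this assay, at which 3 of the 4 values shown sit.

The compounds shown do not tell why the 2-fluorophenyl behaves differently here, or whether a plain phenyl, a chlorophenyl or a methoxyphenyl at this place would also give a number. They also leave open whether the 2-fluorobenzyl would have a similar effect alongside the smaller chains on the core of compound 1 or compound 2.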